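The source may report more compounds than this note shows. Statements on the series, on what has been measured and on what is new or still open speak of the compounds shown alone.

In a functional assay on K562 cells (Homo sapiens) for inhibition, read by fluorescence, with a stated time of 72 h (a higher number here means a weaker inhibitor of growth, a lower number a stronger inhibitor of growth), compound 1 (`COc1ccc(Nc2nc(N[C@H]3CC[C@H](N)CC3)nc3c2ncn3CCC(C)C)c(OC)c1`) gives 5500 nM and compound 2 (`CC(C)CCn1cnc2c(NCc3cccc(Cl)c3)nc(N[C@H]3CC[C@H](N)CC3)nc21`) gives 3100 nM, so these two values lie within the scatter of each other. Compound 3 (`COc1cc(Nc2nc(N[C@H]3CC[C@H](N)CC3)nc3c2ncn3CCC(C)C)cc(OC)c1`) has 3,5-dimethoxyphenyl in place of 3-chlorobenzyl on a nitrogen on an aromatic ring. For the measured compounds named here, only one measured step bears on this exchange, a 1.8-fold lower number from compound 1 to compound 2 (0.25 log units; within the scatter), which joins 3-chlorobenzyl to a different dimethoxyphenyl, 2,4-dimethoxyphenyl, at the same place. That step stayed within the scatter, so no step beyond the scatter is expected in this assay, and no direction can be firmly expected. Going by the values given here, with only this one step as a guide, the estimate leans slightly towards compound 1 at 5500 nM. The expected change is a 1.3-fold higher number from compound 2 to compound 3 (0.11 log units; within the scatter). For compound 3 the estimated value is 4000 nM, with an expected range of 1500 nM to 10000 nM.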

Compound 3, concentration for 50% growth inhibition: 2500 nM
The estimate for compound 3 lay 1.6-fold (0.20 log units) above the measured number; low and high end bracket the measured number.
By their numbers in this assay, from the lowest: compounds 3, 2 and 1 (each within the scatter of the next, the first and the last beyond it).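

In this assay, for the compounds shown here, 3,5-dimethoxyphenyl in place of 2,4-dimethoxyphenyl on the nitrogen gives a 2.2-fold lower number from compound 1 to compound 3 (0.34 log units; beyond the scatter) and is the first step at this position to pass the scatter, so where the two methoxy groups stand on the phenyl ring has a modest bearing on the number. By contrast, 3,5-dimethoxyphenyl in place of 3-chlorobenzyl gives a 1.2-fold lower number from compound 2 to compound 3 (0.09 log units; within the scatter) and so shows no firm difference between these two groups, even though only one of them carries hydrogen-bond acceptors. Nothing measured here gives a reason for either step.

The compounds shown leave open how a single methoxy group on the phenyl ring, an unsubstituted benzyl or a 3,5-dimethoxybenzyl would read at this nitrogen. They also leave open whether the order holds with a longer chain on the shared core.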